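This account rests on a few compounds, and the source may have more. Where it says the series, first, only, none or still open, it means among the compounds named here.

In an assay for inhibition of kynurenine 3-monooxygenase (Homo sapiens), read by mass spectrometry, with a stated time of 1 h (on this read-out lower numbers stand for stronger inhibition and higher numbers for weaker inhibition), compound 2 `Cc1ccnc([C@@H](C)Oc2cc3oc(=O)n(CCC(=O)O)c3cc2Cl)c1` gives 3.98 nM; compound 1 `C[C@@H](Oc1cc2oc(=O)n(CCC(=O)O)c2cc1Cl)c1ccc(F)cn1` gives 2.51 nM, and the two sit within the scatter of each other, the step of a 1.6-fold higher number from compound 1 to compound 2 (0.20 log units; within the scatter) being small. Compound 3 `C[C@@H](Oc1cc2oc(=O)n(CCC(=O)O)c2cc1Cl)c1ncccn1` carries pyrimidin-2-yl in place of 4-methylpyridin-2-yl on a saturated chain carbon bound to an oxygen on an aromatic ring and a saturated chain carbon. Going by the values given here, the only measured step that bears on a change at this place is a 1.6-fold higher number from compound 1 to compound 2 (0.20 log units; within the scatter), an exchange of one six-membered aromatic ring for another, and it did not leave the scatter. For compound 3 the expected step is therefore a 1.3-fold higher number from compound 2 to compound 3 (0.10 log units; within the scatter), no clear move beyond the scatter. Compound 3 is estimated at 5 nM, within a range from 2 nM to 13 nM.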

Compound 3, half-maximal inhibitory concentration in the kynurenine 3-monooxygenase assay: 5.01 nM
Compound 3: the middle estimate sits 1.0-fold (0.00 log units) below what was measured; measured number inside the range.
By their numbers in the kynurenine 3-monooxygenase assay, from the lowest: compounds 1, 2 and 3 (each within the scatter of the next).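

Going by these compounds alone, in the kynurenine 3-monooxygenase assay pyrimidin-2-yl gives a 1.3-fold higher number from compound 2 to compound 3 (0.10 log units; within the scatter) and a 2.0-fold higher number from compound 1 to compound 3 (0.30 log units; within the scatter) and this place therefore takes a ring with 2 hetero atoms with no step leaving the scatter. In a physicochemical assay for lipophilicity, read by HPLC, at pH 7.4 (a lower number here means a more polar compound, a higher number a more lipophilic compound), compound 2 gives 2.15 and compound 3 gives 0.83 and the same exchange gives a clear separation of the two read-outs, with lipophilicity moving while inhibition stays within the scatter: the measured distribution coefficient of compound 2, 2.15, and of compound 3, 0.83, a number 1.32 log units lower (beyond the scatter).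

Still open, from the compounds shown here alone, is whether inhibition stays within the scatter with a group other than a six-membered aromatic ring at this place, such as an amine or a longer chain.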